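Compound 4: Hydroxy to Methoxy

The source may hold more compounds than are shown below. What is called first, only, known or untested is meant among the compounds shown, and "the series" means these compounds.

- compound 1 `O=C(/C(=C\c1ccc(O)c([N+](=O)[O-])c1)SCc1ccc(Cl)cc1)c1ccc(Cl)cc1`: 10000 nM
- compound 2 `COc1ccc(/C=C(/SCc2ccc(Cl)cc2)C(=O)c2ccc(Br)cc2)cc1`: 10000 nM
- compound 3 `O=C(/C(=C\c1ccc(O)cc1)SCc1ccc(Cl)cc1)c1ccc(Cl)cc1`: 10000 nM

In a functional assay on DU-145 cells (Homo sapiens) for inhibition, read by trypan blue exclusion, with a stated time of 96 h (a lower number here means a stronger inhibitor of growth, a higher number a weaker inhibitor of growth), compound 3 gives 10000 nM, which leaves it level with both other measured compounds. Compound 4 `COc1ccc(/C=C(/SCc2ccc(Cl)cc2)C(=O)c2ccc(Cl)cc2)cc1`, not yet measured, differs from compound 3 by methyl in place of hydrogen on an oxygen on an aromatic ring. This places methyl in place of hydrogen on an oxygen on an aromatic ring, turning hydroxy to methoxy.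

Within the data shown here, only one measured step is available, and it lies at another place on the shared core. That step, no change at the digits printed from compound 1 to compound 3 (within the scatter), is hydrogen in place of nitro on an aromatic carbon and stays within the scatter. Among the measured compounds shown here, no measured step touches the oxygen itself, so the evidence is indirect. The flat series gives no reason to expect movement in either direction in this assay. No shift beyond the scatter is expected, and the estimated change is no change at the digits printed from compound 3 to compound 4 (within the scatter). Compound 4 is expected at 10000 nM, with an estimated range from 4000 nM to 20000 nM.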

Compound 4, concentration for 50% growth inhibition: 10000 nM
The estimate for compound 4 equals the measured number at the digits printed, within the range that was stated.
By their numbers in this assay, from the lowest: compounds 1, 2, 3 and 4 (each within the scatter of the next).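

In this assay, the oxygen itself now has a direct reading: methyl in place of hydrogen on this oxygen, turning hydroxy to methoxy, gives a step (no change at the digits printed from compound 3 to compound 4 (within the scatter)) that stays within the scatter. Chloro in place of bromo on an aromatic carbon likewise stays within the scatter (no change at the digits printed from compound 2 to compound 4 (within the scatter)), as does 4-methoxyphenyl in place of 4-hydroxy-3-nitrophenyl (no change at the digits printed from compound 1 to compound 4 (within the scatter)), so none of these three changes separates the compounds in this assay. Nothing available here bears on why the values stay level.

As far as these compounds go, whether an ethyl group or a longer chain on this oxygen, or an amine in place of the hydroxy, would give a step beyond the scatter remains open. The four level values also leave unknown which parts of the shared core, if any, can move the growth-inhibition reading.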